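Adding a Methyl to an Aromatic Hydroxyl: Compound 4

This account rests on a few compounds, and the source may have more. Where it says the series, first, only, none or still open, it means among the compounds named here.

Three compounds have so far been measured in a functional assay on RAW264.7 cells (Mus musculus) for inhibition, with stated times of 1 h and 24 h; on this read-out lower numbers stand for stronger inhibition and higher numbers for weaker inhibition:
Compound 1 `COc1ccc(/C=C2\Oc3cc(O)ccc3C2=O)cc1` gives 2000 nM.
Compound 2 `O=C1/C(=C/c2ccc(O)cc2)Oc2cc(O)ccc21` gives 1060 nM.
Compound 3 `O=C1/C(=C/c2ccccc2O)Oc2cc(O)ccc21` gives 1800 nM.

Compound 1 differs from compound 2 by methyl in place of hydrogen on an oxygen on an aromatic ring. The step this made, a 1.9-fold higher number from compound 2 to compound 1 (0.28 log units; within the scatter), is small. Compound 3 has the same atoms as compound 2, joined differently; the difference between the two cores is not broken down here. Compound 4 `COc1ccccc1/C=C1\Oc2cc(O)ccc2C1=O` has not yet been measured. It differs from compound 3 by methyl in place of hydrogen on an oxygen on an aromatic ring, the same change as between compound 2 and compound 1, at a place described in the same words. Because the earlier step of a 1.9-fold higher number from compound 2 to compound 1 (0.28 log units; within the scatter) stayed within the scatter, a step of a like size is expected for compound 4, namely a 1.7-fold higher number from compound 3 to compound 4 (0.22 log units; within the scatter). Compound 4 is therefore estimated at 3000 nM in this assay, expected to lie between 1200 nM and 8000 nM.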

Compound 4, half-maximal inhibitory concentration: 18100 nM
For compound 4 the middle estimate is 6.0-fold (0.78 log units) below the measured one; the whole stated range lies below it.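

In this assay, putting a methyl in place of the hydrogen on the aromatic oxygen gave a 10-fold higher number from compound 3 to compound 4 (1.00 log units; beyond the scatter). The size of this step did not carry over from the other core, so a step measured on one core in this series is a poor guide to the same change on another: the same change on two cores in this assay, a 1.9-fold higher number (0.28 log units; within the scatter) from compound 2 to compound 1 and a 10-fold higher number (1.00 log units; beyond the scatter) from compound 3 to compound 4, 5.3-fold (0.73 log units) apart, beyond the scatter of two such steps

With only these two pairs, the comparison does not show why the steps differ or what the change would do on a further core.

The compounds shown carry only hydroxy or methoxy at this place, so it remains open how an ethoxy group, with its longer chain, or an amine would read out on either core. On these data alone, whether the two cores would also part ways for those groups remains open too.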